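The source may report more compounds than this note shows. Statements on the series, on what has been measured and on what is new or still open speak of the compounds shown alone.

Compound 1 `CCCCCCCCCCCCCCNc1nc(=O)c2ncn([C@@H]3O[C@H](CO)[C@@H](O)[C@H]3O)c2c(=O)[nH]1`: 300 ug/mL
Compound 2 `CCCCCCCCCCCCCCCCCCNc1nc(=O)c2ncn([C@@H]3O[C@H](CO)[C@@H](O)[C@H]3O)c2c(=O)[nH]1`: > 500 ug/mL

Of the compounds shown here, two have been measured in an assay on isolated protein for inhibition of ATP-dependent RNA helicase SUPV3L1, mitochondrial (Homo sapiens); a higher number here means a weaker inhibitor, a lower number a stronger inhibitor. Compound 1 `CCCCCCCCCCCCCCNc1nc(=O)c2ncn([C@@H]3O[C@H](CO)[C@@H](O)[C@H]3O)c2c(=O)[nH]1` has a long saturated chain on the core, and in this assay compound 1 gives 300 ug/mL. Compound 2 `CCCCCCCCCCCCCCCCCCNc1nc(=O)c2ncn([C@@H]3O[C@H](CO)[C@@H](O)[C@H]3O)c2c(=O)[nH]1` has the same core with a longer chain. In this assay compound 2 reaches only a limit, > 500 ug/mL, and no number is known for it (the limit of > 500 ug/mL in this assay, at which 1 of the 2 values shown sits). Among the measured compounds shown here, the one measured step, an at least 1.6-fold higher number from compound 1 to compound 2 (0.22 log units; that floor lies within the scatter), lengthens the chain and moves the number upward, although its floor lies within the scatter.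

Compound 3 `CCCCCCCCCCNc1nc(=O)c2ncn([C@@H]3O[C@H](CO)[C@@H](O)[C@H]3O)c2c(=O)[nH]1` takes the change in the other direction: hydrogen in place of octyl on a saturated chain carbon, ten or more bonds along the chain from a nitrogen on an aromatic ring. For the measured compounds named here, the shortening is larger than the lengthening seen in the measured step, and no compound with a chain this short has yet been measured. Going by the values given here, on the single step available, a shorter chain is expected to give a lower number in this assay than compound 2 shows, and the estimated step is an at least 2.5-fold lower number from compound 2 to compound 3 (0.39 log units; beyond the scatter). Compound 3 is therefore estimated at 200 ug/mL in this assay, with a range from 70 ug/mL to 500 ug/mL.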

Compound 3, half-maximal inhibitory concentration: > 500 ug/mL
Compound 3: a limit, no number; the forecaster's own chance of this, stated with the estimate: 25%; at least 2.5-fold (0.39 log units) between middle value and limit.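

In this assay compound 3 reaches only a limit, > 500 ug/mL, and no number is known for it. Removing octyl therefore does not bring the lower number that the earlier lengthening suggested, and the comparison with the other measured chain is an at least 1.6-fold higher number from compound 1 to compound 3 (0.22 log units; that floor lies within the scatter): shortening and lengthening the chain on the core of compound 1 both leave a limit rather than a lower number, although neither floor establishes a difference beyond the scatter. Compound 2 and compound 3 cannot be ordered against each other because both values are limits, so the step between them cannot be read: the limit of > 500 ug/mL in this assay, at which 2 of the 3 values shown sit.

On these data alone, what remains open is how large the numbers of compound 2 and compound 3 really are, and therefore whether the chain of compound 1 holds any true advantage over the other two. As far as these compounds go, it is also open how the number would respond to a chain carrying an amine or a carboxylic acid, or to a ring in place of the saturated chain.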